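A few compounds are considered here, and "the series" means these few. Any claim that something is new, unique, unknown or untested is made for them only; others in the source may bear on it.

Measured so far:
compound 1, `COc1ccc(-c2c(-n3ccnc3)oc3cc(OC)ccc3c2=O)cc1`: 2000 nM
compound 2, `O=c1c(-c2ccccc2)c(-n2ccnc2)oc2cc(OCc3ccccc3)ccc12`: 520 nM

In an assay for inhibition of Aromatase (Homo sapiens) (a lower number here means a stronger inhibitor, a higher number a weaker inhibitor), compound 2 gives the lower of the two numbers; the gap to compound 1 lies beyond the scatter. Compound 3, `COc1ccc(-c2c(-n3ccnc3)oc3cc(OCc4ccccc4)ccc3c2=O)cc1`, differs from compound 2 in one place: methoxy in place of hydrogen on an aromatic carbon. Among the measured compounds shown here, no pair of measured compounds isolates this change. Compound 1 and compound 2 differ at two places at once, so what their two values show cannot be assigned to the methoxy on the phenyl alone. The expectation for the step from compound 2 to compound 3 is therefore set close to no change, with a slight lean toward a higher number; the lean rests only on compound 1, which carries the 4-methoxyphenyl group and gives 2000 nM in this assay, and is weak for that reason. Compound 3 is expected at 700 nM, with a range from 250 nM to 2000 nM. The step this estimate implies, a 1.3-fold higher number from compound 2 to compound 3 (0.13 log units; within the scatter), is expected to stay within the usual scatter.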

Compound 3, half-maximal inhibitory concentration: 4700 nM
Compound 3: middle estimate off by 6.7-fold (0.83 log units), on the low side; measured number above the stated range.
By their numbers in this assay, from the lowest: compound 2; then compound 1; then compound 3.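

Working notes on the series: in this assay, the change from phenyl to 4-methoxyphenyl now has a size of its own, with a 9.0-fold higher number from compound 2 to compound 3 (0.96 log units; beyond the scatter), so at this place on the six-membered aromatic ring the added methoxy raises the number beyond the scatter. With the 4-methoxyphenyl group held constant, phenyl in place of hydrogen on a saturated chain carbon bound to an oxygen on an aromatic ring gives a 2.4-fold higher number from compound 1 to compound 3 (0.37 log units; beyond the scatter), also a higher number and also beyond the scatter, so this second change does not offset the loss seen with the methoxy. No measurement at hand accounts for either step.

Among the compounds shown here, still open is whether the methoxy step carries over to the core of compound 1, as the only reading of it comes from the background of compound 2 and compound 3. Also open, going by these compounds, is whether the rise belongs to the methoxy itself or to any group at this place, a question that a fluorine, a hydroxyl or a dimethylamino group on the same ring carbon could address.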